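Working notes: cytotoxicity series, compound 4 pending

The source may report more compounds than this note shows. Statements on the series, on what has been measured and on what is new or still open speak of the compounds shown alone.

Compound 1 `COc1cc(/C=C\c2ccc(C(C)C)cc2)cc(OC)c1OC`: in a functional assay on MLM cells (Homo sapiens) for cytotoxicity, using microsomes (on this read-out lower numbers stand for an effect already at smaller amounts and higher numbers for an effect only at larger amounts of compound), compound 1 gives 7 uM.
Compound 2 `COc1cc(/C=C/c2ccc(C(C)C)cc2)cc(OC)c1OC`: in this assay compound 2 gives > 25 uM, a limit of the assay.
Compound 3 `COc1ccc(/C=C\c2cc(OC)c(OCc3ccccc3)c(OC)c2)cc1`: in this assay compound 3 gives > 25 uM, a limit of the assay.

Within the data shown here, the only single-site step measured is an at least 3.5-fold higher number from compound 1 to compound 2 (0.55 log units; beyond the scatter); it rests on (the fact that compounds 1 and 2 differ only in the configuration as drawn), and its end point is the limit of > 25 uM in this assay, at which 2 of the 3 values shown sit. Compound 2 therefore stands at the limit of the assay, and compound 3 sits at that same limit, so no order between compounds 2 and 3 can be read.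

Compound 4 `CCOc1ccc(/C=C/c2cc(OC)c(OC)c(OC)c2)cc1` differs from compound 2 by ethoxy in place of isopropyl on an aromatic carbon. Among the measured compounds shown here, no measured step covers this replacement; the one measured step concerns only the configuration of the double bond, which compound 4 shares with compound 2. The measured steps thus give no direction for this change, and the expected step that the limit leaves unreadable from compound 2 to compound 4 is taken as none beyond the scatter. Compound 4 is estimated at 30 uM, within 8 uM to 100 uM, and is expected most likely to return again as a limit.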

Compound 4, concentration for half-maximal effect: 2.2 uM
For compound 4 the middle estimate is 14-fold (1.13 log units) above the measured one; the measured number lies below the stated range.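

At this position, on an aromatic carbon para to a large group, the series now has its first readable change of group: in this assay, ethoxy in place of isopropyl gives an at least 11-fold lower number from compound 2 to compound 4 (1.05 log units; beyond the scatter). Compound 4 shares its double-bond configuration with compound 2, so that configuration does not by itself hold a compound at the limit. For compound 2, > 25 uM is a limit of the assay, and the full size of the step stays open because of that limit: the limit of > 25 uM in this assay, at which 2 of the 4 values shown sit.

Which feature of the exchange from isopropyl to ethoxy goes with the step stays open, as this position is represented by these two groups alone. Also open, from the compounds shown here alone, is whether an amine, a hydroxyl or a longer chain such as propoxy at this place would behave like ethoxy or like isopropyl.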